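The source may report more compounds than this note shows. Statements on the series, on what has been measured and on what is new or still open speak of the compounds shown alone.

Compound 1 `Cc1ccc([N+](=O)[O-])cc1S(=O)(=O)N(C)/N=C/c1cnn2ccccc12` gives in an assay on isolated protein for inhibition of phosphatidylinositol 4,5-bisphosphate 3-kinase catalytic subunit beta isoform (Homo sapiens), read by 33P incorporation, with a stated time of 60 min (on this read-out lower numbers stand for stronger inhibition and higher numbers for weaker inhibition), only the limit > 10000 nM. Compound 2 `CC(=O)Oc1ccn2ncc(/C=N/N(C)S(=O)(=O)c3cc([N+](=O)[O-])ccc3C)c2c1` likewise gives only the limit > 1000 nM in this assay. Compound 3 `Cc1ccc([N+](=O)[O-])cc1S(=O)(=O)N(C)/N=C/c1cnn2ccc(Cl)cc12` gives 390 nM in this assay.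

Compound 1 therefore stands at a limit of this assay (the limit of > 10000 nM in this assay, at which 1 of the 3 values shown sits), not at a number, so its place among the three is known only as the weakest-reading end. Compound 4 `Cc1ccc([N+](=O)[O-])cc1S(=O)(=O)N(C)/N=C/c1cnn2ccc(C(N)=O)cc12` differs from compound 1 by carbamoyl in place of hydrogen on an aromatic carbon. For the measured compounds named here, two measured steps bear on the same position: an at least 25-fold lower number from compound 1 to compound 3 (1.40 log units; beyond the scatter), and a step that the two limits leave unreadable from compound 1 to compound 2. The step of an at least 2.5-fold lower number from compound 2 to compound 3 (0.40 log units; beyond the scatter) shows that what enters at this carbon matters. A carbamoyl is expected to lower the number relative to compound 1, though by how much is uncertain. Compound 4 is estimated at 2500 nM, between 400 nM and 15000 nM, a step of an at least 4.0-fold lower number from compound 1 to compound 4 (0.60 log units; beyond the scatter).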

Compound 4, half-maximal inhibitory concentration: > 1000 nM
Compound 4 ended at the assay's limit; the forecaster's own chance of this, stated with the estimate: 35%; the middle value lies beyond the limit too.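

Carbamoyl in place of chloro on this aromatic carbon gives an at least 2.5-fold higher number from compound 3 to compound 4 (0.40 log units; beyond the scatter), so the gain seen with chloro does not extend to carbamoyl. Compound 3 remains the only one of the four with a number rather than a limit, so a group at this carbon does not by itself bring a readable value; acetoxy in compound 2 and carbamoyl in compound 4 both stay at limits.

Going by these compounds, the steps from compound 1 and from compound 2 to compound 4 join two limits and cannot be read, so whether carbamoyl improves on hydrogen stays open. On these data alone, whether bromo, methyl or an amine at this carbon would match chloro also remains unknown.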